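Cyclopropyl in Place of Isopropyl on the Amide Nitrogen

A few compounds are considered here, and "the series" means these few. Any claim that something is new, unique, unknown or untested is made for them only; others in the source may bear on it.

Of the compounds shown here, two of the shared core have been measured in a functional assay on A549 cells (Homo sapiens) for antiproliferative activity, read by CCK-8 assay, with a stated time of 48 h; a lower number here means a stronger inhibitor, a higher number a weaker inhibitor. Compound 1 `O=C(Nc1ccc(Cl)cc1)c1cc(Oc2ccc(/C=C/c3ccncc3)cc2)ccn1` gives 62100 nM in this assay, and compound 2 `CC(C)NC(=O)c1cc(Oc2ccc(/C=C/c3ccncc3)cc2)ccn1` gives 20600 nM. Within the data shown here, the single step between them, a 3.0-fold lower number from compound 1 to compound 2 (0.48 log units; beyond the scatter), came with isopropyl in place of 4-chlorophenyl on an amide-type nitrogen, so compound 2 stands with the lowest of the two numbers, and compound 1 is the nearest with a higher one.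

Compound 3 `O=C(NC1CC1)c1cc(Oc2ccc(/C=C/c3ccncc3)cc2)ccn1` has not yet been measured. It differs from compound 2 as follows: cyclopropyl in place of isopropyl on an amide-type nitrogen. Among the measured compounds shown here, no measured step touches this exact exchange; the only step known, from 4-chlorophenyl to isopropyl, replaced a much larger group and does not bear directly on swapping one three-carbon group for another. Since the two groups match in heavy-atom count, donors and acceptors, a step within the scatter is expected, with no clear direction, so the expected step is a 1.1-fold lower number from compound 2 to compound 3 (0.06 log units; within the scatter). Compound 3 is therefore estimated at 18000 nM in this assay, within a range from 8000 nM to 45000 nM.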

Compound 3, half-maximal inhibitory concentration: 35500 nM
Beside the measured number, compound 3's estimate is 2.0-fold (0.29 log units) below it; the range from low to high includes it.
By their numbers in this assay, from the lowest: compounds 2, 3 and 1 (each within the scatter of the next, the first and the last beyond it).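

In this assay, the exchange of isopropyl for cyclopropyl on the amide-type nitrogen keeps the heavy-atom count and adds a three-membered ring, and it gives a 1.7-fold higher number from compound 2 to compound 3 (0.24 log units; within the scatter), so at this position the ring closure shows no change that can be told from the scatter. Set against 4-chlorophenyl, cyclopropyl gives a 1.7-fold lower number from compound 1 to compound 3 (0.24 log units; within the scatter), which also stays within the scatter; compound 3 therefore cannot be separated from either of the other two compounds, and a 3.0-fold lower number from compound 1 to compound 2 (0.48 log units; beyond the scatter) remains the only step at this nitrogen that lies beyond the scatter. Nothing measured on these compounds speaks to why the three numbers fall as they do.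

The compounds shown leave open how this nitrogen responds to a substituent bearing an amine or a carboxylic acid, or to a longer chain such as n-butyl. Every step shown also sits on the amide-type nitrogen, so they leave open how the numbers in this assay respond to a change elsewhere on the shared core.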